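A few compounds are considered here, and "the series" means these few. Any claim that something is new, unique, unknown or untested is made for them only; others in the source may bear on it.

Compound 3 `Cc1cccc(C(=O)Nc2c(C(O)(C(F)(F)F)C(F)(F)F)ccc3ccccc23)c1` carries a 3-methylphenyl group on the carbonyl carbon of its amide. In a functional assay (Sus scrofa) with sulfonylurea receptors; K-ATP channels (Homo sapiens) as the target (a higher number here means a larger maximal response, a lower number a smaller maximal response), compound 3 gives 97%. Two related compounds set the comparison: compound 1 `CCC(=O)Nc1c(C(O)(C(F)(F)F)C(F)(F)F)ccc2ccccc12` gives 96% in this assay, and compound 2 `CCCC(=O)Nc1c(C(O)(C(F)(F)F)C(F)(F)F)ccc2ccccc12` gives 92%. All three numbers sit close together, and every step between them stays within the scatter: a number 4 percentage points lower from compound 1 to compound 2 (within the scatter), a number 1 percentage points higher from compound 1 to compound 3 (within the scatter) and a number 5 percentage points higher from compound 2 to compound 3 (within the scatter). So compound 3 cannot be told apart from its neighbours.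

Compound 4 `O=C(Nc1c(C(O)(C(F)(F)F)C(F)(F)F)ccc2ccccc12)c1cccc([N+](=O)[O-])c1` differs from compound 3 in one place: nitro in place of methyl on an aromatic carbon. Among the measured compounds shown here, none of the measured steps touches the aromatic ring itself; they exchange the whole group on the carbonyl carbon, and even those larger exchanges moved the maximal response only within the scatter. There is therefore no measured basis for a shift beyond the scatter, and the expected step is a number 3 percentage points lower from compound 3 to compound 4 (within the scatter). Compound 4 is estimated to give 94% in this assay, with an expected range from 80% to 105%.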

Compound 4, largest response reached (reported as efficacy), in percent of the reference or control that the assay uses: 99%
Compound 4: the middle estimate sits 5 percentage points below what was measured; low and high end bracket the measured number.
By their numbers in this assay, from the lowest: compounds 2, 1, 3 and 4 (each within the scatter of the next).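

The earlier steps shown here exchanged the whole group on the carbonyl carbon, whereas this one keeps the ring and alters only an aromatic carbon: nitro in place of methyl gives a number 2 percentage points higher from compound 3 to compound 4 (within the scatter) in this assay. The whole-group exchanges now include a ring bearing nitro, with 3-nitrophenyl in place of propyl giving a number 7 percentage points higher from compound 2 to compound 4 (within the scatter) and 3-nitrophenyl in place of ethyl giving a number 3 percentage points higher from compound 1 to compound 4 (within the scatter). So on this ring, nitro, with more heavy atoms and two hydrogen-bond acceptors, can stand where methyl stood with every step inside the scatter, and no measurement at hand explains this result. Still open, going by these compounds, is whether an amine or a carboxylic acid on the same ring carbon would also stay within the scatter in this assay. Also open, on these data alone, is whether a much longer chain on the carbonyl carbon would do so.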